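A chloro step with no measured starting point

This account rests on a few compounds, and the source may have more. Where it says the series, first, only, none or still open, it means among the compounds named here.

- Compound 1 `O=C(CCCCC1CCSS1)Nc1ccccn1`: "not determined" (no result reported)
- Compound 2 `O=C(CCCCC1CCSS1)Nc1ccc(Cl)cn1`: 2.22%
- Compound 3 `O=C(CCCCC(S)CCS)Nc1ccccn1`: "not determined" (no result reported)

In a functional assay on PC-3 cells (Homo sapiens) for inhibition, read by MTT assay, with a stated time of 24 h, tested at 0.1 ug/mL (on this read-out lower numbers stand for less inhibition of growth and higher numbers for more inhibition of growth at the one concentration tested), compound 3 stands at "not determined" (no result reported), which gives it no place on the scale. Compound 1 is in the same position, with "not determined" (no result reported) as its entry. This leaves a single number in the whole set, and it belongs to compound 2.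

The next compound to be tested is compound 4 `O=C(CCCCC(S)CCS)Nc1ccc(Cl)cn1`. The structural change is chloro in place of hydrogen on an aromatic carbon, two atoms from the ring nitrogen and para to a large group.

Going by the values given here, no measured pair shows what such a change does here, so the data offer no direct guide to its size or direction. Compound 3 also lacks a starting value against which a step could be measured. The working expectation is therefore no step beyond the usual scatter in this assay, with no direction favoured. Compound 2 also carries a chloro and reads 2.22%, so it serves as the only loose anchor, and a low reading seems most likely.

For compound 4 the expected value is 5%, with an estimated range from 0% to 20%.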

Compound 4, percent growth inhibition at one concentration: "not active" (no number reported)
Compound 4 has no reported number here; there is nothing to compare the estimate with.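

Compound 3 and compound 4 have no number in this assay, so no step can be read between them. No other evidence bears on these results. The compounds shown leave open whether chloro in place of hydrogen on the aromatic carbon changes growth inhibition in this series, and in which direction and by how much.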